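Swapping an Aryl Amine for Pyrrolidine on the Shared Core

The compounds below may be only part of what the source reports. "The series", "measured", "known", "first", "only" and "open" are said of these compounds alone.

compound 1, `Cc1ccc(NC2=CC(=O)c3nc4n(c3C2=O)[C@H]2OC[C@@H](O)[C@H]2OC4)cc1C`: 2080 nM
compound 2, `O=C1C=C(NC2CCCCC2)C(=O)c2c1nc1n2[C@H]2OC[C@@H](O)[C@H]2OC1`: > 8000 nM (a limit of the assay)
compound 3, `O=C1C=C(Nc2cccc(F)c2)C(=O)c2c1nc1n2[C@H]2OC[C@@H](O)[C@H]2OC1`: 5500 nM

In a functional assay on MCF7 cells (Homo sapiens) for inhibition, read by sulforhodamine B assay (a higher number here means a weaker inhibitor, a lower number a stronger inhibitor), compound 1 gives 2080 nM. For compound 2 the assay reports only a limit, > 8000 nM. Compound 3 gives 5500 nM, the highest of the two numbers shown, and its nearest neighbour is compound 1, with a 2.6-fold higher number from compound 1 to compound 3 (0.42 log units; beyond the scatter). Between compound 2 and compound 3 the data show an at least 1.4-fold lower number from compound 2 to compound 3 (0.16 log units; that floor lies within the scatter).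

Compound 4, `O=C1C=C(N2CCCC2)C(=O)c2c1nc1n2[C@H]2OC[C@@H](O)[C@H]2OC1`, has not yet been measured in this assay. It differs from compound 3 as follows: pyrrolidin-1-yl in place of (3-fluorophenyl)amino on a double-bonded ring carbon. The measured step closest to this change is the replacement of an aryl group by a saturated ring, where an at least 3.8-fold higher number from compound 1 to compound 2 (0.58 log units; beyond the scatter) ended at the limit of > 8000 nM in this assay, at which 1 of the 3 values shown sits. That comparison points towards a weaker inhibitor when the aromatic ring on the amine nitrogen is given up, and compound 4 also loses the amine hydrogen. Compound 4 is therefore expected to show a 2.2-fold higher number from compound 3 to compound 4 (0.34 log units; beyond the scatter), with a fair chance that only a limit is reported. The estimate for compound 4 is 12000 nM, within a range from 5000 nM to 30000 nM.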

Compound 4, half-maximal inhibitory concentration: > 16000 nM
Compound 4 was reported as a limit; the forecaster's own chance of this, stated with the estimate: 60%; middle value at least 1.3-fold (0.12 log units) from the limit.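

In this assay, setting pyrrolidin-1-yl in place of (3-fluorophenyl)amino on the double-bonded ring carbon gives an at least 2.9-fold higher number from compound 3 to compound 4 (0.46 log units; beyond the scatter), and setting it in place of (3,4-dimethylphenyl)amino gives an at least 7.6-fold higher number from compound 1 to compound 4 (0.88 log units; beyond the scatter). The cyclohexylamino group of compound 2 had shown a saturated ring that keeps the amine hydrogen, whereas pyrrolidin-1-yl, with 0 hydrogen-bond donors, shows that a saturated ring without that hydrogen also gives a weaker inhibitor than either of these two aryl amines. The step between the two saturated groups cannot be read, and for compound 4 the assay gives only a limit: the limit of > 16000 nM in this assay, at which 1 of the 4 values shown sits.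

Still open, from the compounds shown here alone, is how much of the loss at this position goes with the aromatic ring and how much with the amine hydrogen, a question that a methyl(phenyl)amino group, which keeps the ring and gives up the hydrogen, would help to separate. Also open, going by these compounds, is whether a benzylamino group or a morpholin-4-yl group at the same carbon would sit nearer the aryl amines or the saturated groups.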